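Compound 4: 4-ethoxyphenyl in place of thiophen-3-yl

The compounds below may be only part of what the source reports. "The series", "measured", "known", "first", "only" and "open" are said of these compounds alone.

The series keeps a shared core and varies the group on a saturated chain carbon bound to an amine nitrogen in a ring. Compound 1 `CCCCN1CCC(C(=O)Nc2cc(Cl)c(N)cc2OC)CC1` carries propyl there; in a functional assay on the whole organism for antagonist activity, with Mus musculus as the target (on this read-out higher numbers stand for an effect only at larger amounts of compound and lower numbers for an effect already at smaller amounts), compound 1 gives only a limit, > 10 mg/kg. Compound 2 `COc1cc(N)c(Cl)cc1NC(=O)C1CCN(Cc2ccc([N+](=O)[O-])cc2)CC1` carries 4-nitrophenyl, and in this assay compound 2 likewise gives a limit, > 4 mg/kg. Within the data shown here, compound 3 `COc1cc(N)c(Cl)cc1NC(=O)C1CCN(Cc2ccsc2)CC1` carries thiophen-3-yl and is the one member with a number: in this assay compound 3 gives 3.4 mg/kg. The step of an at least 2.9-fold lower number from compound 1 to compound 3 (0.46 log units; beyond the scatter) is at least modest; the step of an at least 1.1-fold lower number from compound 2 to compound 3 (0.07 log units; that floor lies within the scatter) has a floor within the scatter; the step that the two limits leave unreadable from compound 1 to compound 2 cannot be read, since both values sit at limits, the limit of > 10 mg/kg in this assay, at which 1 of the 3 values shown sits, and (the limit of > 4 mg/kg in this assay, at which 1 of the 3 values shown sits).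

Compound 4 `CCOc1ccc(CN2CCC(C(=O)Nc3cc(Cl)c(N)cc3OC)CC2)cc1` differs from compound 3 by 4-ethoxyphenyl in place of thiophen-3-yl on a saturated chain carbon bound to an amine nitrogen in a ring. Among the measured compounds shown here, the nearest measured step is the exchange of one aromatic group for another, an at least 1.1-fold lower number from compound 2 to compound 3 (0.07 log units; that floor lies within the scatter), which shows little beyond its floor; no step between two six-membered aromatic groups is known here. A change beyond the scatter is therefore not expected in either direction. For compound 4 the step expected is a 1.1-fold lower number from compound 3 to compound 4 (0.05 log units; within the scatter). Compound 4 is estimated at 3 mg/kg, within 1 mg/kg to 10 mg/kg.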

Compound 4, dose for half-maximal effect: 6.3 mg/kg
Beside the measured number, compound 4's estimate is 2.1-fold (0.32 log units) below it, within the range that was stated.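

In this assay, 4-ethoxyphenyl with its six-membered aromatic ring of carbon only and 9 heavy atoms replaces thiophen-3-yl with its five-membered aromatic ring and 5 heavy atoms, giving a 1.9-fold higher number from compound 3 to compound 4 (0.27 log units; within the scatter), so this larger group and thiophen-3-yl cannot be told apart at this position. The comparison with propyl is also less firm for this group: an at least 1.5-fold lower number from compound 1 to compound 4 (0.20 log units; that floor lies within the scatter) does not establish a separation, whereas an at least 2.9-fold lower number from compound 1 to compound 3 (0.46 log units; beyond the scatter) does. Compound 2 gives only a limit, so its step to compound 4 cannot be read, and the step between compound 1 and compound 2 stays unreadable for the same kind of reason: the limit of > 4 mg/kg in this assay, at which 1 of the 4 values shown sits.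

The ring and the ethoxy change together in the step from thiophen-3-yl, so a plain phenyl would be needed to separate their contributions. Also open, as far as these compounds go, is whether an amine or a carboxylic acid in place of the ethoxy, or a longer chain in place of the propyl, would shift the number beyond the scatter in either direction.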